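A Smaller Group on a Weak Chalcone

This account rests on a few compounds, and the source may have more. Where it says the series, first, only, none or still open, it means among the compounds named here.

Compound 1 `O=C(/C=C/c1ccc(OCc2ccccc2)cc1)c1ccccc1` was tested in a functional assay on CAL-51 cells (Homo sapiens) for inhibition, read by sulforhodamine B assay, with a stated time of 3 days (on this read-out lower numbers stand for stronger inhibition of growth and higher numbers for weaker inhibition of growth), where compound 1 gives 24700 nM. This is the only measured number shown; the other entry is a limit. Compound 2 `Cc1ccc(COc2ccc(C(=O)/C=C/c3ccc(Cl)cc3)cc2)cc1` gave only a limit of > 50000 nM in this assay. One entry sits at the limit of > 50000 nM in this assay, at which 1 of the 2 values shown sits. Compound 3 `O=C(/C=C/c1ccc(Cl)cc1)c1ccccc1` is not yet measured. It differs from compound 1 by chloro in place of benzyloxy on an aromatic carbon. Among the compounds with values here, with no measured step to lean on, the size of any change in this assay is open; the expected step is a 1.4-fold higher number from compound 1 to compound 3 (0.15 log units; within the scatter), which stays within scatter. Compound 3 is estimated at 35000 nM, within a range from 10000 nM to 100000 nM.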

Compound 3, concentration for 50% growth inhibition: 5850 nM
Estimate against measurement, compound 3: 6.0-fold (0.78 log units) above, outside the stated range (below it).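

In this assay, this place on the aromatic ring now has its first measured step, and replacing benzyloxy with chloro gives a 4.2-fold lower number from compound 1 to compound 3 (0.63 log units; beyond the scatter). The benzyloxy group and its extra ring are therefore not needed for growth inhibition in this pair, and a single chlorine atom does better there. Nothing shown explains this step.

From the compounds shown here alone, whether an amine, a carboxylic acid or a methoxy group at this place would do better or worse remains open. This single pair also cannot show whether the gain holds on any other core.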